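This account rests on a few compounds, and the source may have more. Where it says the series, first, only, none or still open, it means among the compounds named here.

Compound 3 `O=C(CCCCCCCCc1ccccc1)c1nc2ncccc2o1` is the most potent of the three measured compounds in an assay on HEK-293T cells for inhibition of diacylglycerol lipase-alpha (Homo sapiens), read by colorimetric assay; a higher number here means a weaker inhibitor, a lower number a stronger inhibitor: compound 3 gives 3.63 nM. The other two compounds share the core of compound 1 instead. In this assay compound 1 `O=Cc1coc(C(=O)CCCCCCc2ccccc2)n1` gives 1510 nM, and compound 2 `CN(C)C(=O)c1coc(C(=O)CCCCCCc2ccccc2)n1` gives 3390 nM. Going by the values given here, the only single-change step among the measured compounds, a 2.2-fold higher number from compound 1 to compound 2 (0.35 log units; beyond the scatter), concerns a dimethylamino group on a carbonyl carbon of that other core; it does not touch the chain.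

Compound 4 `CCCCCCCCCCCC(=O)c1nc2ncccc2o1` keeps the core of compound 3 and changes only the far end of the chain: propyl in place of phenyl on a saturated chain carbon, eight bonds along the chain from a carbonyl carbon. Among the compounds with values here, no measured pair tests this kind of change, so the expectation rests on compound 3 alone, with the other two compounds giving only the scale of numbers on a weaker core. Removing the phenyl without any measured precedent leaves the direction open, and a small loss is estimated, a 2.8-fold higher number from compound 3 to compound 4 (0.44 log units; beyond the scatter). Compound 4 is therefore expected to give about 10 nM in this assay, with a range from 2 nM to 60 nM.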

Compound 4, half-maximal inhibitory concentration: 30.9 nM
Compound 4: the middle estimate sits 3.1-fold (0.49 log units) below what was measured, within the range that was stated.
By their numbers in this assay, from the lowest: compound 3; then compound 4; then compound 1; then compound 2.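

In this assay, propyl in place of phenyl on a saturated chain carbon, eight bonds along the chain from a carbonyl carbon, gives an 8.5-fold higher number from compound 3 to compound 4 (0.93 log units; beyond the scatter), so what sits at this far end of the chain clearly affects the result. Even with no ring at that end, compound 4 gives 30.9 nM, which shows that the phenyl is not essential for a value in this range. No supporting measurement is available to explain this step.

This single change swaps a ring for an open chain and also alters the number of heavy atoms, so the two effects cannot be separated. A cyclohexyl group at the same place would test whether the ring needs to be aromatic, while a longer chain ending in pentyl would test the effect of size without any ring.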